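The source may hold more compounds than are shown below. What is called first, only, known or untested is meant among the compounds shown, and "the series" means these compounds.

Compound 1 `CCCCCN(CCCCC)C(=O)N1CCN(C(=O)N(c2ccccc2)c2ccccc2)[C@H](C(=O)O)C1`: in an assay on CHO cells for binding affinity to Substance-P receptor (Homo sapiens) (on this read-out higher numbers stand for weaker inhibition and lower numbers for stronger inhibition), compound 1 gives 130 nM.
Compound 2 `CCCCCN(CCCCC)C(=O)N1CCN(C(=O)N(c2ccccc2)c2ccccc2)[C@H](CO)C1`: in this assay compound 2 gives 280 nM.
Compound 3 `CCCCCN(CCCCC)C(=O)N1CCN(C(=O)N(c2ccccc2)c2ccccc2)[C@H](C(=O)NCCN(C)C)C1`: in this assay compound 3 gives 55 nM.

Compound 3 has the lowest number of the three. The steps leading to it are a 2.4-fold lower number from compound 1 to compound 3 (0.37 log units; beyond the scatter) and a 5.1-fold lower number from compound 2 to compound 3 (0.71 log units; beyond the scatter); the remaining step is a 2.2-fold higher number from compound 1 to compound 2 (0.33 log units; beyond the scatter). Going by the values given here, all three compounds share one core and differ only in the group on one ring carbon, and the amide carrying a basic side chain gave the lowest number so far.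

Compound 4 `CCCCCN(CCCCC)C(=O)N1CCN(C(=O)N(c2ccccc2)c2ccccc2)[C@H](C(=O)NCCNCc2ccccc2OC)C1` differs from compound 3 in one place: (2-methoxybenzyl)amino in place of dimethylamino on a saturated chain carbon, two bonds along the chain from an amide-type nitrogen. The amide and its chain are kept; only the outer end of the chain is exchanged. Among the compounds with values here, none of the measured steps changes that outer end, so they give no direct guide to the size or direction of this step. What they show is that the side chain as a whole brought a modest gain over the acid and the alcohol, which suggests the chain is tolerated and a change at its far end need not be large.

Compound 4 is therefore expected to change by a 1.2-fold lower number from compound 3 to compound 4 (0.09 log units; within the scatter) in this assay, a step not clearly beyond the scatter. The estimate for compound 4 is 45 nM, with a range from 15 nM to 140 nM.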

Compound 4, half-maximal inhibitory concentration: 9 nM
Estimate against measurement, compound 4: 5.0-fold (0.70 log units) above; measured number below the stated range.
By their numbers in this assay, from the lowest: compound 4; then compound 3; then compound 1; then compound 2.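

The far end of the side chain is not a neutral spot: in this assay, (2-methoxybenzyl)amino in place of dimethylamino gives a 6.1-fold lower number from compound 3 to compound 4 (0.79 log units; beyond the scatter), a step beyond the scatter. The earlier compounds shown here changed only the group on the ring carbon, so they could say nothing about this outer end, whereas here a group of 10 heavy atoms with a six-membered aromatic ring replaces one of 3 heavy atoms with no ring, and the number falls rather than rises. No measurement at hand explains this drop.

The exchange alters several things at once, including the ring, the methoxy group and the hydrogen on the nitrogen, so these compounds cannot show which of them goes with the lower number. A plain benzylamino group would test the methoxy group alone, a methylamino group would test the nitrogen hydrogen without the ring, and a three-carbon chain in place of the two-carbon one would show whether the distance from the amide also counts.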